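The source may hold more compounds than are shown below. What is called first, only, known or untested is meant among the compounds shown, and "the series" means these compounds.

Compound 2 `Cc1cc(NC(=O)Cn2nnc(-c3cccc(C#N)c3)n2)n(C2CCCCC2)n1` gives 183 nM in an assay on HEK293 cells for activation of Kir3.1/Kir3.2 (Homo sapiens), read by thallium flux (on this read-out higher numbers stand for an effect only at larger amounts of compound and lower numbers for an effect already at smaller amounts), and stands with compound 1 `Cc1cc(NC(=O)Cn2nnc(-c3ccc(C(F)(F)F)cc3)n2)n(C2CCCCC2)n1`, which gives 241 nM, the two values lying within the scatter of each other, as the step of a 1.3-fold lower number from compound 1 to compound 2 (0.12 log units; within the scatter) shows. Compound 3 `Cc1cc(NC(=O)Cn2nnc(-c3ccc(Cl)c(C)c3)n2)n(C2CCCCC2)n1` carries the change (4-chloro-3-methylphenyl in place of 3-cyanophenyl on an aromatic carbon). Among the measured compounds shown here, the single measured step that bears on it, a 1.3-fold lower number from compound 1 to compound 2 (0.12 log units; within the scatter), also exchanged one aryl substituent pattern for another and moved the number little, so no step beyond the scatter is expected in this assay here either. Compound 3 is therefore estimated at 220 nM, with a range from 90 nM to 550 nM. The expected step is a 1.2-fold higher number from compound 2 to compound 3 (0.08 log units; within the scatter).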

Compound 3, half-maximal effective concentration: 712 nM
Compound 3: middle estimate off by 3.2-fold (0.51 log units), on the low side; measured number outside the range, above it.
By their numbers in this assay, from the lowest: compounds 2 and 1 (each within the scatter of the next); then compound 3.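

In this assay the aryl group on the aromatic carbon between two ring nitrogen atoms can shift the number: 4-chloro-3-methylphenyl brings a 3.9-fold higher number from compound 2 to compound 3 (0.59 log units; beyond the scatter) and a 3.0-fold higher number from compound 1 to compound 3 (0.47 log units; beyond the scatter) and so stands apart from the two earlier aryl groups, which lie within the scatter of each other. Both steps are modest, yet this position is not as tolerant of aryl exchange as the first pair suggested. No supporting data explain the shift.

From the compounds shown here alone, whether the chlorine, the methyl or the two together carry the step remains open. Also open, going by these compounds, is how an amine or a carboxylic acid on this aryl ring would read.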